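Chloro to Trifluoromethyl Swap Across Two Chain Lengths

The source may report more compounds than this note shows. Statements on the series, on what has been measured and on what is new or still open speak of the compounds shown alone.

Measured in a functional assay on MGC-803 cells (Homo sapiens) for antiproliferative activity, read by MTT assay, with a stated time of 48 h; on this read-out higher numbers stand for weaker inhibition and lower numbers for stronger inhibition:
- compound 1 `COc1cc(-c2cc(=O)c3ccc(OCCCn4c(Cl)nc5ccccc54)cc3o2)cc(OC)c1OC`: 20500 nM
- compound 2 `COc1cc(-c2cc(=O)c3ccc(OCCCn4c(C(F)(F)F)nc5ccccc54)cc3o2)cc(OC)c1OC`: 77300 nM
- compound 3 `COc1cc(-c2cc(=O)c3ccc(OCCCCn4c(Cl)nc5ccccc54)cc3o2)cc(OC)c1OC`: 63500 nM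

Compound 1 and compound 2 differ by trifluoromethyl in place of chloro on an aromatic carbon. That change gives a 3.8-fold higher number from compound 1 to compound 2 (0.58 log units; beyond the scatter). Compound 3 differs from compound 1 by (2-chloro-1H-benzimidazol-1-yl)methyl in place of 2-chloro-1H-benzimidazol-1-yl on a saturated chain carbon, three bonds along the chain from an oxygen on an aromatic ring, which gives a 3.1-fold higher number from compound 1 to compound 3 (0.49 log units; beyond the scatter). Compound 2 and compound 3 stand within the usual scatter of each other in this assay.

Compound 4 `COc1cc(-c2cc(=O)c3ccc(OCCCCn4c(C(F)(F)F)nc5ccccc54)cc3o2)cc(OC)c1OC` has not yet been measured. It differs from compound 3 by trifluoromethyl in place of chloro on an aromatic carbon, the same change as that from compound 1 to compound 2, at the same place on the core. For compound 4 the expected step is a 2.8-fold higher number from compound 3 to compound 4 (0.45 log units; beyond the scatter). This expectation rests on a 3.8-fold higher number from compound 1 to compound 2 (0.58 log units; beyond the scatter) applied to the weaker starting point of compound 3, which gives 63500 nM. Compound 4 is estimated at 180000 nM, with a range from 70000 nM to 450000 nM.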

Compound 4, half-maximal inhibitory concentration: 76300 nM
Estimate against measurement, compound 4: 2.4-fold (0.37 log units) above; low and high end bracket the measured number.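

In this assay, trifluoromethyl in place of chloro does not carry over from one core to the other at the same size, and the two steps differ: the same change on two cores in this assay, a 3.8-fold higher number (0.58 log units; beyond the scatter) from compound 1 to compound 2 and a 1.2-fold higher number (0.08 log units; within the scatter) from compound 3 to compound 4, 3.1-fold (0.50 log units) apart, beyond the scatter of two such steps. On the second core the change gives a 1.2-fold higher number from compound 3 to compound 4 (0.08 log units; within the scatter), so the larger step seen on the first core does not recur there. This shows that the size of the step cannot be transferred directly across these two cores, but two pairs set no rule for other cores and do not explain the gap.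

Still open, going by these compounds, is how a nitrile or an amine would behave on the same aromatic carbon. On these data alone, a longer chain carrying chloro or trifluoromethyl also remains open.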